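Trifluoromethyl Added to the Phenethyl Amide of Compound 2

A few compounds are considered here, and "the series" means these few. Any claim that something is new, unique, unknown or untested is made for them only; others in the source may bear on it.

Measured compounds:
compound 1, `Cc1ccc(C(CCN(C)C)NC(=O)CCc2ccc(C(F)(F)F)cc2)cc1`, 2290 nM
compound 2, `CN(C)CCC(NC(=O)CCc1ccccc1)c1ccc(Cl)cc1`, 1660 nM
compound 3, `CN(C)CCC(NC(=O)/C=C/c1ccccc1)c1ccc(Cl)cc1`, 427 nM

In a functional assay on NIH3T3 cells for agonist activity at Urotensin-2 receptor (Homo sapiens), with a stated time of 5 days (a lower number here means that less compound is needed, a higher number that more compound is needed for the effect), compound 2 gives 1660 nM, the second highest of the three numbers; its nearest neighbour is compound 1, and the two lie within the scatter of each other, while compound 3 sits further off, with a 3.9-fold lower number from compound 2 to compound 3 (0.59 log units; beyond the scatter). The unmeasured compound 4, `CN(C)CCC(NC(=O)CCc1ccc(C(F)(F)F)cc1)c1ccc(Cl)cc1`, differs from compound 2 by trifluoromethyl in place of hydrogen on an aromatic carbon. Among the compounds with values here, no measured step covers exactly this change. The closest evidence is indirect: compound 1 carries the same trifluoromethyl group on its phenethyl amide, with a methyl in place of the chlorine on the other ring, and in this assay compound 1 gives 2290 nM, within the scatter of compound 2. On that basis compound 4 is expected to show a step of a 1.2-fold higher number from compound 2 to compound 4 (0.08 log units; within the scatter), that is, no movement beyond the scatter. The estimate for compound 4 is therefore 2000 nM, with a range from 900 nM to 4500 nM.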

Compound 4, half-maximal effective concentration: 1120 nM
The estimate for compound 4 lay 1.8-fold (0.25 log units) above the measured number; the range from low to high includes it.
By their numbers in this assay, from the lowest: compound 3; then compounds 4, 2 and 1 (each within the scatter of the next, the first and the last beyond it).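

In this assay the step for trifluoromethyl in place of hydrogen, on an aromatic carbon para to a large group, is a 1.5-fold lower number from compound 2 to compound 4 (0.17 log units; within the scatter) and so shows no clear change. The phenethyl amide therefore carries this group at this position without any shift beyond the scatter, which compound 1 alone could not show, since it also differs from compound 2 by a methyl in place of the chloro. With trifluoromethyl held constant, chloro in place of methyl on an aromatic carbon now reads separately as a 2.0-fold lower number from compound 1 to compound 4 (0.31 log units; beyond the scatter) and is a modest step just beyond the scatter.

The compounds shown leave open whether a methoxy, a nitrile or a carboxylic acid at this position would behave alike, and whether trifluoromethyl would give the same result on the 2-phenylethenyl amide of compound 3. Nothing available here accounts for either step.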